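The compounds below may be only part of what the source reports. "The series", "measured", "known", "first", "only" and "open" are said of these compounds alone.

Measured compounds:
compound 1, `COc1ccc(C(=O)c2ccc3c(c2)C=CC(C)(C)O3)c(NC(=O)CO)c1`, 240 nM in a functional assay on HeLa cells (Homo sapiens) for antiproliferative activity, read by MTT assay, with a stated time of 48 h; a higher number here means a weaker inhibitor, a lower number a stronger inhibitor
compound 2, `COc1ccc(C(=O)c2ccc3c(c2)C=CC(C)(C)O3)c(NC(=O)CN)c1`, 580 nM in this assay
compound 3, `C=C(c1cc(OC)c(OC)c(OC)c1)c1ccc(OC)cc1NC(=O)CO`, 30 nM in this assay

Compound 2 is compound 1 with one change, (amino in place of hydroxy on a saturated chain carbon bound to a carbonyl carbon), and that change gave a 2.4-fold higher number from compound 1 to compound 2 (0.38 log units; beyond the scatter). Compound 3 stands on a different core; how the core of compound 3 differs from the core of compound 1 is not broken down here, but in this assay compound 3 gives the lowest number of the three, beyond the scatter against both compound 1 and compound 2.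

Compound 4, `C=C(c1cc(OC)c(OC)c(OC)c1)c1ccc(OC)cc1NC(=O)CN`, is compound 3 with the same change, (amino in place of hydroxy on a saturated chain carbon bound to a carbonyl carbon), made at the same place. Compound 4 is expected to follow the earlier step, because a 2.4-fold higher number from compound 1 to compound 2 (0.38 log units; beyond the scatter) was modest, so the estimate for compound 4 is 70 nM, from 35 nM to 150 nM, which means an expected step of a 2.3-fold higher number from compound 3 to compound 4 (0.37 log units; beyond the scatter).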

Compound 4, half-maximal inhibitory concentration: 70 nM
Estimate against measurement, compound 4: no gap at the digits printed; measured number inside the range.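

In this assay, amino in place of hydroxy on a saturated chain carbon bound to a carbonyl carbon gave a 2.3-fold higher number from compound 3 to compound 4 (0.37 log units; beyond the scatter), a modest step. Set beside the earlier step, the change carried over from one core to the other with no difference beyond the scatter: the same change on two cores in this assay, a 2.4-fold higher number (0.38 log units; beyond the scatter) from compound 1 to compound 2 and a 2.3-fold higher number (0.37 log units; beyond the scatter) from compound 3 to compound 4, 1.0-fold (0.02 log units) apart, within the scatter of two such steps. This shows that one change behaved alike on two cores in one cell assay, but it does not show that the same would hold on any further core, and it does not explain the step.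

The compounds shown leave open how a methylamino group, a carboxylic acid or a longer chain carrying the amine would read on either core.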